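The compounds below may be only part of what the source reports. "The series", "measured", "known", "first", "only" and "open" are said of these compounds alone.

Compound 1 `CCCCC(OC)c1cccc(NC(=O)CCl)c1` and compound 3 `CCCCC(OC)c1cccc(NC(=O)CCCl)c1` share one core and differ only in the acyl chain. In a functional assay on M21 cells (Homo sapiens) for antiproliferative activity, with a stated time of 48 h (a higher number here means a weaker inhibitor, a lower number a stronger inhibitor), compound 1 gives 6900 nM. For compound 3 the result in this assay is a limit of the assay, > 100000 nM, rather than a number. The change between them, (chloromethyl in place of chloro on a saturated chain carbon bound to a carbonyl carbon), thus brings an at least 14-fold higher number from compound 1 to compound 3 (1.16 log units; beyond the scatter), and the size of that step is set by the limit of > 100000 nM in this assay, at which 1 of the 3 values shown sits.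

Compound 2 `O=C(CCCl)Nc1ccc(I)cc1` rests on a different core, and the difference between the two cores is not broken down here. In this assay compound 2 gives 20000 nM, the weaker of the two numbers that this set of compounds provides.

Compound 4 `O=C(CCCCl)Nc1ccc(I)cc1` is not yet measured. It differs from compound 2 by chloromethyl in place of chloro on a saturated chain carbon, two bonds along the chain from a carbonyl carbon. Among the compounds with values here, this is the same kind of change as the one from compound 1 to compound 3, but not the same: there the chloromethyl enters on a saturated chain carbon bound to a carbonyl carbon, whereas here it enters on a saturated chain carbon two bonds along the chain from a carbonyl carbon.

Since compound 2 already starts from 20000 nM and the step from compound 1 to compound 3 was an at least 14-fold higher number from compound 1 to compound 3 (1.16 log units; beyond the scatter), the step from compound 2 to compound 4 in this assay is expected to be a 3.5-fold higher number from compound 2 to compound 4 (0.54 log units; beyond the scatter). For compound 4 in this assay the estimate is 70000 nM, with a range from 25000 nM to 150000 nM, and a fair chance that only a limit is reported.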

Compound 4, half-maximal inhibitory concentration: > 100000 nM
Compound 4 gave a limit, no number; the forecaster's own chance of this, stated with the estimate: 45%; at least 1.4-fold (0.15 log units) between middle value and limit.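

In this assay, chloromethyl in place of chloro again brings a weaker result, with an at least 5.0-fold higher number from compound 2 to compound 4 (0.69 log units; beyond the scatter), so the direction of the change holds on both cores shown, even though it enters one chain carbon further along in this pair: the same change on two cores in this assay, an at least 14-fold higher number (1.16 log units; beyond the scatter) from compound 1 to compound 3 and an at least 5.0-fold higher number (0.69 log units; beyond the scatter) from compound 2 to compound 4; the limit leaves it open whether they differ

This does not show how large either step really is, or whether the size carries over from one core to the other, since compound 3 and compound 4 each end in a limit of the assay rather than a number: the limit of > 100000 nM in this assay, at which 2 of the 4 values shown sit.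

Two pairs on two cores therefore support only a shared direction for this change, not a rule for the series or a fixed size for the step.

The compounds shown leave open how the shortest acyl chain, the one carried by compound 1, would behave on the core of compound 2, and so whether that core also gives its lowest number with this chain. They also leave open what follows when the chlorine at the end of the chain gives way to another group, such as a bromine or an amine, on either core.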